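Aryl groups on the amine of a coumarin propargylamine

The source may report more compounds than this note shows. Statements on the series, on what has been measured and on what is new or still open speak of the compounds shown alone.

Measured compounds:
compound 1 `C#CCN(C)CCCCOc1ccc2ccc(=O)oc2c1`: 3280 nM
compound 2 `C#CCN(CCCCOc1ccc2ccc(=O)oc2c1)Cc1ccccc1`: 89400 nM

In an ADME assay on isolated protein for inhibition of Amine oxidase [flavin-containing] A (Homo sapiens), read by fluorescence and Amplex Red, with stated times of 15 min and 20 min (on this read-out higher numbers stand for weaker inhibition and lower numbers for stronger inhibition), compound 1 gives 3280 nM, the lowest of the two numbers; compound 2 gives 89400 nM. Among the measured compounds shown here, the one measured step, a 27-fold higher number from compound 1 to compound 2 (1.44 log units; beyond the scatter), arises from phenyl in place of hydrogen on a saturated chain carbon bound to an amine nitrogen. Compound 3 `C#CCN(CCCCOc1ccc2ccc(=O)oc2c1)Cc1cccc(OC)c1` differs from compound 1 by 3-methoxyphenyl in place of hydrogen on a saturated chain carbon bound to an amine nitrogen. Since that change shares the benzyl part of the step to compound 2, compound 3 is expected to show a rise of similar size, an 18-fold higher number from compound 1 to compound 3 (1.26 log units; beyond the scatter), giving an estimated 60000 nM in this assay, in the range 15000 nM to 250000 nM.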

Compound 3, half-maximal inhibitory concentration: 78600 nM
For compound 3 the middle estimate is 1.3-fold (0.12 log units) below the measured one, and the stated range covers the measured number.
By their numbers in this assay, from the lowest: compound 1; then compounds 3 and 2 (each within the scatter of the next).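

In this assay, 3-methoxybenzyl in place of methyl also brings a large rise (a 24-fold higher number from compound 1 to compound 3 (1.38 log units; beyond the scatter)), so at this position the rise is not confined to the plain benzyl group. Compounds 2 and 3 stand within the usual scatter of each other (a 1.1-fold lower number from compound 2 to compound 3 (0.06 log units; within the scatter)), so methoxy in place of hydrogen on an aromatic carbon gives no readable difference. Nothing given here accounts for either step. Still open, as far as these compounds go, is how an ethyl group on the amine nitrogen would read, and whether a fluorobenzyl or a phenethyl group would match the benzyl compounds.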